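A few compounds are considered here, and "the series" means these few. Any claim that something is new, unique, unknown or untested is made for them only; others in the source may bear on it.

Measured compounds:
- compound 1, `COc1ccc2c(c1)c(/C=N\NC(=O)c1c[nH]c3ccc(Br)cc13)cn2Cc1ccc(Cl)cc1`, 26300 nM
- compound 2, `COc1ccc2c(c1)c(/C=N\NC(=O)c1c[nH]c3ccccc13)cn2Cc1ccc(Cl)cc1`, 26700 nM
- compound 3, `COc1ccc(Cn2cc(/C=N\NC(=O)c3c[nH]c4ccc(Br)cc34)c3ccc(F)cc32)cc1`, 45500 nM

In a functional assay on MIA PaCa-2 cells (Homo sapiens) for cytotoxicity (a lower number here means a stronger inhibitor, a higher number a weaker inhibitor), compound 1 gives 26300 nM and compound 2 gives 26700 nM. Between them lies one change, (hydrogen in place of bromo on an aromatic carbon), and the step it made is a 1.0-fold higher number from compound 1 to compound 2 (0.01 log units; within the scatter). Compound 3, which gives 45500 nM, has a different core; the difference between the two cores is not broken down here, and the numbers of compound 3 and compound 2 lie within the scatter of each other.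

Compound 4, `COc1ccc(Cn2cc(/C=N\NC(=O)c3c[nH]c4ccccc34)c3ccc(F)cc32)cc1`, has not been measured. Within the data shown here, it differs from compound 3 by hydrogen in place of bromo on an aromatic carbon, the same change as the one from compound 1 to compound 2, sitting at a place described in the same words. Because the earlier step of a 1.0-fold higher number from compound 1 to compound 2 (0.01 log units; within the scatter) was flat, the step from compound 3 to compound 4 in this assay is expected to be about a 1.0-fold higher number from compound 3 to compound 4 (0.00 log units; within the scatter) as well. On that basis compound 4 is estimated at 46000 nM, with a likely range from 20000 nM to 100000 nM.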

Compound 4, half-maximal inhibitory concentration: 43300 nM
Beside the measured number, compound 4's estimate is 1.1-fold (0.03 log units) above it; the measured number falls inside the stated range.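

In this assay, replacing the bromo group with hydrogen, which turns 5-bromo-1H-indol-3-yl into 1H-indol-3-yl, gives a 1.1-fold lower number from compound 3 to compound 4 (0.02 log units; within the scatter), so this step is as flat as the earlier one. The two cores agree on this change: the same change on two cores in this assay, a 1.0-fold higher number (0.01 log units; within the scatter) from compound 1 to compound 2 and a 1.1-fold lower number (0.02 log units; within the scatter) from compound 3 to compound 4, 1.1-fold (0.03 log units) apart, within the scatter of two such steps.

Within these two pairs, then, the bromo group can be exchanged for hydrogen with no readable shift in cytotoxicity, and the flat result carries from one core to the other. This does not show that the change would stay flat on a third core, and because neither step moves the number, it cannot tell whether a change that does have a real effect would carry over in the same way.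

From the compounds shown here alone, only bromo and hydrogen appear at this place on the ring, so what a nitrile, an amine or a carboxylic acid would do there remains open. Whether the same flat step would appear in any other kind of cell is also left open.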